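Compound 3 gains a (chloromethyl)carbonyl group

This account rests on a few compounds, and the source may have more. Where it says the series, first, only, none or still open, it means among the compounds named here.

Three measured compounds share one core and differ only in the group on one nitrogen. In a functional assay on K562 cells (Homo sapiens) for antiproliferative activity, read by MTT assay (a higher number here means a weaker inhibitor, a lower number a stronger inhibitor), compound 1 `O=C1NC(c2ccccc2)CN1S(=O)(=O)c1ccc2c(c1)CCCN2` gives > 20000 nM, which is a limit of the assay and not a number. In the same test compound 2 `O=C(OCCCl)N1CCCc2cc(S(=O)(=O)N3CC(c4ccccc4)NC3=O)ccc21` gives 10600 nM, and compound 3 `NC(=O)N1CCCc2cc(S(=O)(=O)N3CC(c4ccccc4)NC3=O)ccc21` gives 3660 nM. For the measured compounds named here, compound 3 therefore holds the lowest number so far, making it the strongest inhibitor of the three.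

Compound 4 `O=C(CCl)NC(=O)N1CCCc2cc(S(=O)(=O)N3CC(c4ccccc4)NC3=O)ccc21` is built from compound 3 by one change: (chloromethyl)carbonyl in place of hydrogen on an amide-type nitrogen. In words, this is (chloromethyl)carbonyl in place of hydrogen on an amide-type nitrogen.

Going by the values given here, no measured step makes this exact change, so the evidence is indirect. Replacing the hydrogen of compound 1 gave an at least 5.4-fold lower number from compound 1 to compound 3 (0.73 log units; beyond the scatter), while the other replacement gave an at least 1.8-fold lower number from compound 1 to compound 2 (0.27 log units; that floor lies within the scatter), whose floor lies within the scatter. Swapping groups on the carbonyl carbon gave a 2.9-fold lower number from compound 2 to compound 3 (0.46 log units; beyond the scatter). These steps show that changes in this part of the molecule can lower the number, though only modestly where the size is known. A small further drop is thus the likeliest outcome, with a rise still possible. The expected change is a 1.8-fold lower number from compound 3 to compound 4 (0.26 log units; within the scatter), which is a small step. Compound 4 is estimated at 2000 nM, with an expected range of 500 nM to 8000 nM.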

Compound 4, half-maximal inhibitory concentration: 515 nM
Compound 4: middle estimate off by 3.9-fold (0.59 log units), on the high side; the range from low to high includes it.
By their numbers in this assay, from the lowest: compound 4; then compound 3; then compound 2. At a limit, above all of these: compound 1.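

In this assay, for the compounds shown here, adding (chloromethyl)carbonyl on the amide-type nitrogen gives a 7.1-fold lower number from compound 3 to compound 4 (0.85 log units; beyond the scatter), which shows that this nitrogen, untouched in the earlier compounds, can carry a further group while the number still falls. Compound 2 and compound 4 both carry a chlorine, yet ((chloromethyl)carbonyl)amino in place of 2-chloroethoxy gives a 21-fold lower number from compound 2 to compound 4 (1.31 log units; beyond the scatter), and compound 3 has no chlorine and still holds a lower number than compound 2, so having a chlorine somewhere in this group does not by itself give the low number, while the whole group on the shared core gives an at least 38-fold lower number from compound 1 to compound 4 (1.58 log units; beyond the scatter). Compound 1 reads as a limit and not a number, which makes that last step a floor: the limit of > 20000 nM in this assay, at which 1 of the 4 values shown sits.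

The compounds shown leave open whether the chlorine in the new group matters at all, since an acetyl group, with a plain methyl in place of the chloromethyl, would separate the chlorine from the added carbonyl. A longer chain carrying its chlorine further out, such as 3-chloropropanoyl, or a bromoacetyl group on the same nitrogen, would show how far this step can be pushed.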